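A few compounds are considered here, and "the series" means these few. Any claim that something is new, unique, unknown or untested is made for them only; others in the source may bear on it.

Of the compounds shown here, two have been measured in an ADME assay on the whole organism (plasma, Macaca fascicularis) for protein binding, read by LC-MS, using equilibrium dialysis and cassette dosing, with a stated time of 24 h, at a dose of 1 mg/kg by the oral route; a lower number here means a smaller unbound share, a higher number a larger unbound share of the compound. Compound 1 `C[C@H](c1ccc(-c2ccccc2-c2nc(=O)o[nH]2)cc1)N(CC1CC1)c1nc2c(C(=O)O)cccc2o1` gives 0.0000851 in this assay. Compound 2 `CCCCN(c1nc2c(-c3nccn3C)cccc2o1)[C@H](C)c1ccc(-c2ccccc2-c2nnn[nH]2)cc1` gives 0.00299 in this assay, the higher of the two numbers. The gap between compound 2 and compound 1 lies beyond the scatter of repeated measurements. Compound 3 `CCCCN(c1nc2c(C(=O)N(C)C)cccc2o1)[C@H](C)c1ccc(-c2ccccc2-c2nnn[nH]2)cc1` has not yet been measured. It differs from compound 2 in one place: dimethylcarbamoyl in place of 1-methyl-1H-imidazol-2-yl on an aromatic carbon. Among the measured compounds shown here, no measured pair in the set shows this exchange, so the size of the step has no direct precedent here. Because compound 2 gives 0.00299 and the rest of the molecule is kept intact, a step of modest size, in either direction and not clearly beyond the scatter, is expected for a 1.3-fold higher number from compound 2 to compound 3 (0.13 log units; within the scatter). Compound 3 is expected to give about 0.004 in this assay, with a likely range from 0.0015 to 0.011.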

Compound 3, unbound fraction: 0.00411
Beside the measured number, compound 3's estimate is 1.0-fold (0.01 log units) below it; measured number inside the range.
By their numbers in this assay, from the lowest: compound 1; then compounds 2 and 3 (each within the scatter of the next).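

In this assay, placing dimethylcarbamoyl in place of 1-methyl-1H-imidazol-2-yl on this aromatic carbon gives a 1.4-fold higher number from compound 2 to compound 3 (0.14 log units; within the scatter), so the unbound fraction stays within the scatter across this exchange. Among the compounds shown here, with the rest of the molecule kept intact, this position therefore accepts either an aromatic five-membered ring or an open-chain amide without a measurable difference in this read-out, something the earlier compounds could not show, as they differ in more than one place. Nothing available here explains this outcome.

Left open is whether a primary amine or a nitrile on this same aromatic carbon would also stay within the scatter of compound 2. One exchange also cannot show whether the same result would hold with a different chain in place of the butyl group.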